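The source may hold more compounds than are shown below. What is called first, only, known or untested is meant among the compounds shown, and "the series" means these compounds.

The study spans two cores. Compound 1 `CS/C(=N\C(=O)c1csc([N+](=O)[O-])c1)NC(=O)c1csc([N+](=O)[O-])c1` carries one of them, and in a functional assay on PC-3 cells (Homo sapiens) for cytotoxicity, read by MTT assay, with a stated time of 72 h (a lower number here means a stronger inhibitor of growth, a higher number a weaker inhibitor of growth), compound 1 gives 41500 nM. Compound 2 `CS/C(=N\C(=O)c1ccco1)NC(=O)c1ccco1` carries the other core, and the difference between the two cores is not broken down here. In this assay compound 2 gives 56200 nM, which lies within the scatter of the number for compound 1. Compound 3 `O=C(/N=C(/NC(=O)c1ccco1)[Se]Cc1ccccc1)c1ccco1` differs from compound 2 by the change (a group of 8 heavy atoms (7 carbon, 1 selenium; one six-membered aromatic ring of carbon only) in place of a group of 2 heavy atoms (1 carbon, 1 sulfur; no ring), on a carbon with a double bond to nitrogen). In this assay compound 3 gives 30500 nM, and the step amounts to a 1.8-fold lower number from compound 2 to compound 3 (0.27 log units; within the scatter). Compound 4 `O=C(/N=C(/NC(=O)c1csc([N+](=O)[O-])c1)[Se]Cc1ccccc1)c1csc([N+](=O)[O-])c1` stands to compound 1 as compound 3 stands to compound 2, with the change a group of 8 heavy atoms (7 carbon, 1 selenium; one six-membered aromatic ring of carbon only) in place of a group of 2 heavy atoms (1 carbon, 1 sulfur; no ring), on a carbon with a double bond to nitrogen at a place described in the same words, so it is the same change seen a second time. Because the earlier instance gave a 1.8-fold lower number from compound 2 to compound 3 (0.27 log units; within the scatter), a step of similar size is expected in this assay, namely a 1.7-fold lower number from compound 1 to compound 4 (0.22 log units; within the scatter). For the measured compounds named here, the sole precedent is within the scatter, so the expectation is loose. Compound 4 is therefore estimated at 25000 nM in this assay, with a range from 10000 nM to 60000 nM.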

Compound 4, concentration for 50% growth inhibition: 35900 nM
Estimate against measurement, compound 4: 1.4-fold (0.16 log units) below; the range from low to high includes it.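

In this assay, the group of 8 heavy atoms with its six-membered aromatic ring, in place of methylsulfanyl on the core of compound 1, amounts to a 1.2-fold lower number from compound 1 to compound 4 (0.06 log units; within the scatter). Set beside the same change on the other core, the two steps do not differ: the same change on two cores in this assay, a 1.8-fold lower number (0.27 log units; within the scatter) from compound 2 to compound 3 and a 1.2-fold lower number (0.06 log units; within the scatter) from compound 1 to compound 4, 1.6-fold (0.20 log units) apart, within the scatter of two such steps. For the compounds shown here, the change therefore reads alike on both cores, but each step is small enough to lie within the scatter, so this does not show that the change lowers the number on either core, and the agreement rests on only two cores and this one assay.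

The compounds shown leave open whether selenium or the aromatic ring matters more, since the two enter together and a group carrying the same ring on sulfur does not appear among them. Also open, as far as these compounds go, is how an amine or a longer carbon chain on a carbon with a double bond to nitrogen would read in this assay, and whether the match would hold on a third core.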